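A few compounds are considered here, and "the series" means these few. Any claim that something is new, unique, unknown or untested is made for them only; others in the source may bear on it.

Working notes on the series, read in a physicochemical assay for solubility, in phosphate buffer, measured as kinetic solubility, at pH 7.4, tested at 250 uM (on this read-out lower numbers stand for lower solubility and higher numbers for higher solubility), throughout. Compound 1 (`CCCCCCNc1ccc([N+](=O)[O-])cc1S(N)(=O)=O`) gives 6000 nM in this read-out. Compound 2 (`CCCCCCCCNc1ccc([N+](=O)[O-])cc1S(N)(=O)=O`) gives < 1000 nM as a limit of the assay and not as a number. Compound 3 (`CCCCCCNc1ccc(C(=O)O)cc1S(N)(=O)=O`) gives 238000 nM and so holds the higher of the two actual numbers in the series. Its nearest neighbour is compound 1, and carboxy in place of nitro on an aromatic carbon accounts for a 40-fold higher number from compound 1 to compound 3 (1.60 log units; beyond the scatter) as the gap between them.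

The open question is compound 4 (`CCCCCCCCNc1ccc(C(=O)O)cc1S(N)(=O)=O`), which differs by ethyl in place of hydrogen on a saturated chain carbon, six bonds along the chain from a nitrogen on an aromatic ring on the carboxy member of the series. Among the compounds with values here, only one measured step involves this same change, namely an at least 6.0-fold lower number from compound 1 to compound 2 (0.77 log units; beyond the scatter) on the nitro side. That step rests on a limit and comes from a single pair, and the change has not yet been measured with carboxy in place. The step between the nitro and carboxy compounds sets the starting point but is a different change. A lower number, beyond the scatter and of similar size to the nitro step, is therefore expected, with an estimated 6.0-fold lower number from compound 3 to compound 4 (0.77 log units; beyond the scatter) in this assay as the working figure. The estimate for compound 4 is 40000 nM with 10000 nM to 150000 nM as the expected range.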

Compound 4, solubility: > 250000 nM
Compound 4 ended at the assay's limit; the forecaster's own chance of this, stated with the estimate: 10%; middle value at least 6.2-fold (0.79 log units) away from the limit.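

The reading for compound 4 is a limit of the assay and not a number: the limit of > 250000 nM in this assay, at which 1 of the 4 values shown sits. On the carboxy side, ethyl in place of hydrogen at this chain position shows none of the lowering seen on the nitro side, where the step is an at least 6.0-fold lower number from compound 1 to compound 2 (0.77 log units; beyond the scatter); here it reads an at least 1.0-fold higher number from compound 3 to compound 4 (0.02 log units; that floor lies within the scatter), so the direction of the nitro step does not carry over to the carboxy pair. Carboxy in place of nitro keeps the direction it has in a 40-fold higher number from compound 1 to compound 3 (1.60 log units; beyond the scatter) on the pair with the longer chain, at an at least 250-fold higher number from compound 2 to compound 4 (2.39 log units; beyond the scatter), although both ends of that step are limits.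

As far as these compounds go, how far compound 4 lies past its limit remains unknown, so the data cannot separate a true rise on adding ethyl from no change, and the size of that step on the carboxy side stays unset. Also open, from the compounds shown here alone, is whether a longer chain on the carboxy compounds, or an amine or a primary amide in place of carboxy, would follow the carboxy or the nitro pattern in this assay.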